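A Second Hydroxy Group on the Phenyl Ring

The compounds below may be only part of what the source reports. "The series", "measured", "known", "first", "only" and "open" are said of these compounds alone.

Compound 1 `Cc1c(C(=O)N/N=C\c2ccc(C(F)(F)F)cc2)oc2cccc(O)c12` — in a functional assay on PC-3 cells (Homo sapiens) for inhibition (a higher number here means a weaker inhibitor, a lower number a stronger inhibitor), compound 1 reaches only the limit >= 40000 nM.
Compound 2 `Cc1c(C(=O)N/N=C\c2ccccc2O)oc2cccc(O)c12` — compound 2 gives 8350 nM.
Compound 3 `Cc1c(C(=O)N/N=C\c2cc([N+](=O)[O-])ccc2O)oc2cccc(O)c12` — compound 3 gives 17100 nM.

Compound 2 stands at the lowest of the two numbers that were actually measured; its nearest neighbour is compound 3, which sits a 2.0-fold higher number from compound 2 to compound 3 (0.31 log units; beyond the scatter). The value of compound 1 is a limit of this assay and not a number (the limit of >= 40000 nM in this assay, at which 1 of the 3 values shown sits).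

Compound 4 `Cc1c(C(=O)N/N=C\c2ccc(O)cc2O)oc2cccc(O)c12` differs from compound 2 in one place: hydroxy in place of hydrogen on an aromatic carbon. For the measured compounds named here, only one measured step touches this ring at all, the nitro step from compound 2 to compound 3, and it is modest and points toward a weaker inhibitor. It involves a different group at a different place, so it bears on the hydroxy change only loosely. The expected step is therefore small, a 1.1-fold higher number from compound 2 to compound 4 (0.03 log units; within the scatter), and may well lie within the scatter. Going by the values given here, compound 4 is estimated at 9000 nM in this assay, with a range from 3500 nM to 22000 nM, because the one comparable step a 2.0-fold higher number from compound 2 to compound 3 (0.31 log units; beyond the scatter) was modest.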

Compound 4, half-maximal inhibitory concentration: 14800 nM
Estimate against measurement, compound 4: 1.6-fold (0.22 log units) below, and the stated range covers the measured number.
By their numbers in this assay, from the lowest: compounds 2, 4 and 3 (each within the scatter of the next, the first and the last beyond it). At a limit, above all of these: compound 1.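

In this assay, the change from 2-hydroxyphenyl to 2,4-dihydroxyphenyl gives a 1.8-fold higher number from compound 2 to compound 4 (0.25 log units; within the scatter), so no real change can be claimed for this hydroxy group, which sits para to a large group and meta to a hydroxy group. For the compounds shown here, this is the first reading at this place on the ring, and it shows that a hydroxy group can stand here without a loss that rises above the scatter, whereas the nitro step, a 2.0-fold higher number from compound 2 to compound 3 (0.31 log units; beyond the scatter), made at a different place, lies beyond it. Nothing in the data shown bears on why this step is so small.

As far as these compounds go, it remains open whether another group at this same place, such as an amine, a methoxy group or a carboxylic acid, would move the number beyond the scatter. Also open, from the compounds shown here alone, is what this hydroxy group would do on a phenyl ring that lacks the 2-hydroxy group.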